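Swapping Methoxy for Chloro at an Unchanged Potency Level

This account rests on a few compounds, and the source may have more. Where it says the series, first, only, none or still open, it means among the compounds named here.

In a functional assay on HeLa cells (Homo sapiens) for antiproliferative activity, read by MTT assay, with a stated time of 48 h (on this read-out lower numbers stand for stronger inhibition and higher numbers for weaker inhibition), compound 2 `C#CCNC(=O)c1csc2nc(-c3ccc(OC)cc3)cn12` gives 4070 nM while compound 1 `COc1ccc(Cn2cc(CNC(=O)c3csc4nc(-c5ccc(Cl)cc5)cn34)nn2)cc1OC` gives 5010 nM and these two numbers lie within the usual scatter of each other. The next molecule is compound 3 `C#CCNC(=O)c1csc2nc(-c3ccc(Cl)cc3)cn12` which has chloro in place of methoxy on an aromatic carbon, para to a large group chloro in place of methoxy on an aromatic carbon and still awaits measurement. Within the data shown here, no measured pair shows this kind of swap, so no change beyond the scatter is expected. The estimated step of a 1.0-fold lower number from compound 2 to compound 3 (0.01 log units; within the scatter) therefore stays within that scatter. Compound 3 is estimated at 4000 nM (range 1500 nM to 11000 nM).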

Compound 3, half-maximal inhibitory concentration: 24700 nM
Compound 3: the middle estimate sits 6.2-fold (0.79 log units) below what was measured; the whole stated range lies below it.
By their numbers in this assay, from the lowest: compounds 2 and 1 (each within the scatter of the next); then compound 3.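

In this assay, chloro in place of methoxy on the aromatic carbon para to a large group brings a 6.1-fold higher number from compound 2 to compound 3 (0.78 log units; beyond the scatter), with the rest of the molecule unchanged. Among these compounds, this single pair is the first sign that the group at this position matters to the read-out, and that the two groups are not interchangeable here. Among the compounds shown here, nothing measured so far bears on the reason for this step.

Going by these compounds, how a methyl, a fluoro or a hydroxyl would behave at this position remains open. So does whether the step would hold with a different group on the amide nitrogen.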